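Fluorine shift on a phenoxy group in an inactive series

The source may report more compounds than this note shows. Statements on the series, on what has been measured and on what is new or still open speak of the compounds shown alone.

Compound 3 `Cc1ccc(OC[C@@H]2[C@H]3CC[C@H](c4nc(C(=O)O)cs4)O[C@H]3C[C@H]2O)cc1` carries a 4-methylphenoxy group on the shared core. In an assay on HEK293 cells for agonist activity at prostaglandin E2 receptor EP2 subtype (Homo sapiens), read by a beta-galactosidase reporter and beta-arrestin recruitment, with a stated time of 90 min (on this read-out lower numbers stand for an effect already at smaller amounts and higher numbers for an effect only at larger amounts of compound), compound 3 gives only a limit, > 10000 nM. Compound 1 `O=C(O)c1csc([C@H]2CC[C@@H]3[C@@H](COc4ccc(C(F)(F)F)cc4)[C@H](O)C[C@@H]3O2)n1` also gives only a limit in this assay, > 10000 nM. Compound 2 `O=C(O)c1csc([C@H]2CC[C@@H]3[C@@H](COc4ccccc4F)[C@H](O)C[C@@H]3O2)n1` likewise gives only a limit in this assay, > 10000 nM. Because all three values sit at the limit of > 10000 nM in this assay, at which 3 of the 3 values shown sit, the steps a step that the two limits leave unreadable from compound 1 to compound 2, a step that the two limits leave unreadable from compound 1 to compound 3 and a step that the two limits leave unreadable from compound 2 to compound 3 cannot be read, and nothing on the numbers shown sets the three aryl groups apart. Compound 4 `O=C(O)c1csc([C@H]2CC[C@@H]3[C@@H](COc4cccc(F)c4)[C@H](O)C[C@@H]3O2)n1` differs from compound 3 by 3-fluorophenyl in place of 4-methylphenyl on an oxygen on a saturated carbon. The measured steps that bear on this change, the exchanges of one aryl group for another among compounds 1, 2 and 3, all end at the limit, so no size can be assigned to any of them. Compound 4 is therefore expected to stay at the limit as well, with the step that the limit leaves unreadable from compound 3 to compound 4 estimated as nothing that can be read. The estimate for compound 4 in this assay is 15000 nM, from 4000 nM to 60000 nM.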

Compound 4, half-maximal effective concentration: > 10000 nM
Compound 4: only a limit was reported (the forecaster's own chance of this, stated with the estimate: 85%); the middle value lies beyond the limit too.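

The result for compound 4 is only a limit, as are those for compound 1, compound 2 and compound 3, so the steps from each of these to compound 4 cannot be read: the limit of > 10000 nM in this assay, at which 4 of the 4 values shown sit.

The compounds shown leave open whether any of these four aryl groups differs from another in this assay, and at what concentration, if any, an effect would appear.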